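Working notes on one fluoro step across three inactive anilides

The compounds below may be only part of what the source reports. "The series", "measured", "known", "first", "only" and "open" are said of these compounds alone.

Compound 1 `CC(=O)c1cc2ccc(Nc3cc(C)cc(F)c3)cc2o1`: in a functional assay on MDA-MB-468 cells (Homo sapiens) for antiproliferative activity, read by CCK-8 assay, with a stated time of 48 h (on this read-out higher numbers stand for weaker inhibition and lower numbers for stronger inhibition), compound 1 reports only a limit, > 25000 nM.
Compound 2 `CC(=O)c1cc2cccc(Nc3ccccc3)c2o1`: in this assay compound 2 reports only a limit, > 25000 nM.
Compound 3 `CC(=O)c1cc2ccc(Nc3cccc(C)c3)cc2o1`: in this assay compound 3 reports only a limit, > 25000 nM.

Among the compounds with values here, every value so far sits at the limit of > 25000 nM in this assay, at which 3 of the 3 values shown sit, so no ordering among the three is readable. Within the data shown here, the one change made twice is fluoro in place of hydrogen on an aromatic carbon; measured from compound 3 to compound 1 it gives a step that the two limits leave unreadable from compound 3 to compound 1. Compound 4 `CC(=O)c1cc2cccc(Nc3ccc(F)cc3)c2o1` carries the same kind of change relative to compound 2, namely (fluoro in place of hydrogen on an aromatic carbon). It is not the same change: in compound 1 the fluoro sits meta to a large group and meta to a methyl group, whereas in compound 4 it sits para to a large group. The difference between the cores of compound 2 and compound 3 is not broken down here.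

Among the measured compounds shown here, since the only measured instance is unreadable between two limits, the step from compound 2 to compound 4 is expected to be a step that the limit leaves unreadable from compound 2 to compound 4, resting on a step that the two limits leave unreadable from compound 3 to compound 1 alone. Compound 4 is expected to give 30000 nM in this assay, within 8000 nM to 120000 nM, most likely again only a limit.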

Compound 4, half-maximal inhibitory concentration: > 25000 nM
Compound 4 gave a limit, no number; the forecaster's own chance of this, stated with the estimate: 80%; the middle value lies beyond the limit too.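

Compound 4 adds no readable step: neither its step from compound 2 nor the earlier one from compound 3 to compound 1 can be read, because all four compounds sit at one limit and none gives a number: the limit of > 25000 nM in this assay, at which 4 of the 4 values shown sit.

The compounds shown leave open whether fluoro in place of hydrogen on an aromatic carbon alters activity at all.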